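This account rests on a few compounds, and the source may have more. Where it says the series, first, only, none or still open, it means among the compounds named here.

Measured so far in an assay on HEK293 cells for inhibition of sodium channel protein type 3 subunit alpha (Homo sapiens), read by electrophysiology, with a stated time of 3.5 min; a lower number here means a stronger inhibitor, a higher number a weaker inhibitor:

- compound 1, `C[C@H](NC1CCOc2cc(OCc3ccccc3F)ccc21)C(N)=O`: compound 1 gives > 79400 nM
- compound 2, `NC(=O)[C@@H]1CC[C@H](c2ccc(OCc3ccc(F)cc3)cc2)N1`: compound 2 gives > 63000 nM

Neither entry is a number. For compound 1 the result > 79400 nM is a limit of this assay, as recorded in the limit of > 79400 nM in this assay, at which 1 of the 2 values shown sits. For compound 2 the result > 63000 nM is likewise a limit of this assay, as recorded in the limit of > 63000 nM in this assay, at which 1 of the 2 values shown sits. Going by the values given here, compound 2 therefore stands at the weak end of what this assay can report; no measured step connects it to compound 1, and the two values show only that both compounds sit at limits.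

Compound 3, `NC(=O)[C@@H]1CC[C@H](c2ccc(OCc3cccc(F)c3)cc2)N1`, has not yet been measured. It differs from compound 2 in one place, (3-fluorophenyl in place of 4-fluorophenyl on a saturated chain carbon bound to an oxygen on an aromatic ring). Among the compounds with values here, with both known compounds at limits and no measured step, no direction can be read from the data, and the step from compound 2 to compound 3 is expected to lie within the scatter, most probably as another limit. The step that the limit leaves unreadable from compound 2 to compound 3 is the estimate implied. Compound 3 is estimated at 70000 nM, with a range from 30000 nM to 200000 nM.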

Compound 3, half-maximal inhibitory concentration: > 100000 nM
Compound 3 ended at the assay's limit; the forecaster's own chance of this, stated with the estimate: 80%; middle value at least 1.4-fold (0.15 log units) from the limit.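

In this assay compound 3 gives > 100000 nM, a limit and not a number. Going by these compounds alone, compound 2 gives > 63000 nM, also a limit, so no step between compound 2 and compound 3 can be read. The compounds shown leave open whether 3-fluorophenyl and 4-fluorophenyl differ at all in this assay.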